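From amino to bromo on the shared core

This account rests on a few compounds, and the source may have more. Where it says the series, first, only, none or still open, it means among the compounds named here.

In an ADME assay on L6 cells (Rattus norvegicus) for cytotoxicity (a lower number here means a stronger inhibitor, a higher number a weaker inhibitor), compound 3 `CC1CCc2ccccc2N1S(=O)(=O)c1ccc(N)cc1` gives 35300 nM, the middle of the three measured numbers. Compound 1 `COc1ccc(S(=O)(=O)N2c3ccccc3CCC2C)cc1` gives 5990 nM, and compound 2 `CC1CCc2ccccc2N1S(=O)(=O)c1ccc([N+](=O)[O-])cc1` gives 248000 nM. Compound 4 `CC1CCc2ccccc2N1S(=O)(=O)c1ccc(Br)cc1` has not yet been measured. It carries bromo in place of amino on an aromatic carbon, para to a large group: bromo in place of amino on an aromatic carbon.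

Among the compounds with values here, no measured compound carries bromo, so the evidence is indirect. Three steps at this same carbon bear on the change: the large 41-fold higher number from compound 1 to compound 2 (1.62 log units; beyond the scatter), the modest 5.9-fold higher number from compound 1 to compound 3 (0.77 log units; beyond the scatter) and the modest 7.0-fold lower number from compound 2 to compound 3 (0.85 log units; beyond the scatter). All three lie beyond the scatter, so a change here is expected to register, but none of them fixes the direction for bromo. A modest step to a lower number in this assay is tentatively expected, leaning toward compound 1 at 5990 nM. The estimate corresponds to a 2.4-fold lower number from compound 3 to compound 4 (0.37 log units; beyond the scatter). Compound 4 is expected at about 15000 nM, within an estimated range of 4000 nM to 60000 nM.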

Compound 4, half-maximal inhibitory concentration: 7360 nM
The estimate for compound 4 lay 2.0-fold (0.31 log units) above the measured number; low and high end bracket the measured number.
By their numbers in this assay, from the lowest: compounds 1 and 4 (each within the scatter of the next); then compound 3; then compound 2.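

In this assay bromo at this carbon falls with methoxy and apart from amino and nitro: a 1.2-fold higher number from compound 1 to compound 4 (0.09 log units; within the scatter) stays within the scatter, while a 4.8-fold lower number from compound 3 to compound 4 (0.68 log units; beyond the scatter) and a 34-fold lower number from compound 2 to compound 4 (1.53 log units; beyond the scatter) both lie beyond it. Until now every replacement at this carbon had moved the number beyond the scatter, whereas compound 4 shows that two different groups here can give values that cannot be told apart. No measured property is available to account for this grouping.

Going by these compounds, whether chloro, a carboxylic acid or a longer alkyl chain at this carbon would fall with compound 1 and compound 4 or with the other two remains open. The compounds shown also leave open whether bromo in place of amino would give a similar step on a different core.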